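Compound 3 to compound 4: swapping the aromatic substituent

The source may report more compounds than this note shows. Statements on the series, on what has been measured and on what is new or still open speak of the compounds shown alone.

Measured in a functional assay on HL-60 cells (Homo sapiens) for antiproliferative activity, with a stated time of 72 h; on this read-out lower numbers stand for stronger inhibition and higher numbers for weaker inhibition:
- compound 1 `CCCCC#Cc1cc([C@@H]2O[C@H](CO)[C@@H](O)[C@H]2O)n2ncnc(N)c12`: 400 nM
- compound 2 `Nc1ncnn2c([C@@H]3O[C@H](CO)[C@@H](O)[C@H]3O)cc(C#CC3CC3)c12`: 40 nM
- compound 3 `Nc1ncnn2c([C@@H]3O[C@H](CO)[C@@H](O)[C@H]3O)cc(C#Cc3cccs3)c12`: > 100000 nM (a limit, not a number)

Compound 3 stands at the limit of > 100000 nM in this assay, at which 1 of the 3 values shown sits. Among the measured compounds shown here, its true position is therefore unknown, and it is the only one of the three compounds without a numerical value.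

Next in the series is compound 4 `Nc1ncnn2c([C@@H]3O[C@H](CO)[C@@H](O)[C@H]3O)cc(-c3ccccc3)c12`, with phenyl in place of 2-(thiophen-2-yl)ethynyl on an aromatic carbon.

For the measured compounds named here, no measured step removes the triple bond, so the evidence is indirect. The closest steps are an at least 250-fold higher number from compound 1 to compound 3 (2.39 log units; beyond the scatter) and an at least 2500-fold higher number from compound 2 to compound 3 (3.39 log units; beyond the scatter), both large, where thiophen-2-yl entered on the triple-bonded carbon. The third, a 10-fold lower number from compound 1 to compound 2 (1.00 log units; beyond the scatter), is modest and exchanges only butyl and cyclopropyl, so it says little about this change.

Compound 4 also carries an aromatic ring, so it is expected to stay weak, at or near the limit, rather than approach compound 1 or compound 2. For compound 4 the expected change is an at least 5.0-fold lower number from compound 3 to compound 4 (0.69 log units; beyond the scatter), and it may not be resolved if only a limit is returned. For compound 4 the estimated value is 20000 nM, with an expected range from 1000 nM to 100000 nM.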

Compound 4, half-maximal inhibitory concentration: > 100000 nM
Compound 4: no number, only a limit; the forecaster's own chance of this, stated with the estimate: 45%; at least 5.0-fold (0.69 log units) between middle value and limit.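

In this assay compound 4 returns > 100000 nM, a limit and not a number, so phenyl set on this aromatic carbon without any triple bond gives no readable antiproliferative activity. Exchanging the alkynyl groups of the two measured compounds for phenyl gives an at least 2500-fold higher number from compound 2 to compound 4 (3.39 log units; beyond the scatter) and an at least 250-fold higher number from compound 1 to compound 4 (2.39 log units; beyond the scatter), so among the four compounds, both of those with an aromatic ring at this position stand apart from the butyl and cyclopropyl alkynes, with or without the triple bond. Compound 3 and compound 4 sit at the same limit, so the step between them cannot be read and neither can be placed relative to the other: the limit of > 100000 nM in this assay, at which 2 of the 4 values shown sit.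

Going by these compounds, it remains open how far above this limit compound 3 and compound 4 lie, and whether the aromatic ring itself or the loss of the alkyl end separates them from compound 1 and compound 2. A cyclohexyl group on the same aromatic carbon, or a longer chain or an amine-bearing chain on the triple-bonded carbon, would help to separate these possibilities.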